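The compounds below may be only part of what the source reports. "The series", "measured", "known", "first", "only" and "open" are said of these compounds alone.

In a functional assay on MCF7 cells (Homo sapiens) for inhibition (on this read-out higher numbers stand for weaker inhibition and lower numbers for stronger inhibition), compound 3 `CC/C(=C(/c1ccc(/C=C/C(=O)O)cc1)c1cc2ccccc2[nH]1)c1ccc(Cl)cc1Cl` gives 11 nM, the lowest number of the three measured, while compound 1 `CC/C(=C(/c1ccc(/C=C/C(=O)O)cc1)c1cc2ccccc2[nH]1)c1ccccc1Cl` gives 42 nM and compound 2 `CC/C(=C(/c1ccc(/C=C/C(=O)O)cc1)c1cc2ccccc2[nH]1)c1ccc(C(F)(F)F)cc1` gives 139 nM. Compound 4 `CC/C(=C(/c1ccc(/C=C/C(=O)O)cc1)c1cc2ccccc2[nH]1)c1ccc(Cl)c(C(F)(F)F)c1` carries 4-chloro-3-(trifluoromethyl)phenyl in place of 2,4-dichlorophenyl on a double-bonded chain carbon bound to a double-bonded chain carbon and a saturated chain carbon. Among the measured compounds shown here, two measured steps bear on this change: a 3.8-fold lower number from compound 1 to compound 3 (0.58 log units; beyond the scatter), so giving up the chloro that distinguishes compound 3 from compound 1 is expected to cost roughly that much, and a 3.3-fold higher number from compound 1 to compound 2 (0.52 log units; beyond the scatter), where a ring bearing trifluoromethyl in place of one bearing chlorine raised the number. The wider span is set by a 13-fold lower number from compound 2 to compound 3 (1.10 log units; beyond the scatter). A modest rise is therefore expected, a 3.6-fold higher number from compound 3 to compound 4 (0.56 log units; beyond the scatter). In this assay compound 4 is estimated at 40 nM, within 15 nM to 120 nM.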

Compound 4, half-maximal inhibitory concentration: 2200 nM
Compound 4: middle estimate off by 55-fold (1.74 log units), on the low side, outside the stated range (above it).
By their numbers in this assay, from the lowest: compound 3; then compound 1; then compound 2; then compound 4.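

At the double-bonded chain carbon, the ring change gives a 200-fold higher number from compound 3 to compound 4 (2.30 log units; beyond the scatter) and is the largest step in the series, so this position tolerates some chlorinated rings far better than 4-chloro-3-(trifluoromethyl)phenyl. The same ring also gives a 16-fold higher number from compound 2 to compound 4 (1.20 log units; beyond the scatter) and a 52-fold higher number from compound 1 to compound 4 (1.72 log units; beyond the scatter) in this series. Chloro and trifluoromethyl together on the ring therefore give the highest number, not a value among those of the rings carrying only one kind of group.

As far as these compounds go, whether a methoxy or an amine in place of that trifluoromethyl would bring the number back towards compound 3 stays open. Nothing available explains the size of the jump.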